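The source may report more compounds than this note shows. Statements on the series, on what has been measured and on what is new or still open speak of the compounds shown alone.

Compound 1 `CCCCCCCCCCCCCCCCOP(=O)(O)OCCSC(=S)N1CCCCCC1` gives 17600 nM
Compound 2 `CCCCCCCCCCOP(=O)(O)OCCSC(=S)N1CCCCCC1` gives 24000 nM
Compound 3 `CCCCCCCCOP(=O)(O)OCCSC(=S)N1CCCCCC1` gives 59100 nM

All three values come from a functional assay on DU-145 cells (Homo sapiens) for inhibition, read by MTT assay, with stated times of 18 h and 4 h (a higher number here means a weaker inhibitor, a lower number a stronger inhibitor), and belong to one series that differs only in chain length. Compound 3, at 59100 nM, has the highest number and is the weakest inhibitor of the three. Compound 4 `CCCCCCOP(=O)(O)OCCSC(=S)N1CCCCCC1` has hydrogen in place of ethyl on a saturated chain carbon, six bonds along the chain from an oxygen on an unsaturated carbon.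

The closest guide is the same exchange made eight bonds along the chain, which gave a 2.5-fold higher number from compound 2 to compound 3 (0.39 log units; beyond the scatter) and counts as modest. The larger cut gave a 3.4-fold higher number from compound 1 to compound 3 (0.53 log units; beyond the scatter) in the same direction. Against any simple trend, a 1.4-fold higher number from compound 1 to compound 2 (0.13 log units; within the scatter) stays within the scatter, so shortening does not always register. For the measured compounds named here, a further modest loss therefore seems likely, resting mainly on a 2.5-fold higher number from compound 2 to compound 3 (0.39 log units; beyond the scatter) as the only precedent for this exchange. The expected change is a 2.1-fold higher number from compound 3 to compound 4 (0.33 log units; beyond the scatter) as a rough estimate. For compound 4 the estimated value is 125000 nM with an expected range from 65000 nM to 280000 nM as its limits.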

Compound 4, half-maximal inhibitory concentration: 77400 nM
The estimate for compound 4 lay 1.6-fold (0.21 log units) above the measured number, within the range that was stated.
By their numbers in this assay, from the lowest: compounds 1 and 2 (each within the scatter of the next); then compounds 3 and 4 (each within the scatter of the next).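

In this assay hydrogen in place of ethyl on a saturated chain carbon, six bonds along the chain from an oxygen on an unsaturated carbon, gives a 1.3-fold higher number from compound 3 to compound 4 (0.12 log units; within the scatter) and so this single cut does not separate the two compounds. Larger cuts do register, with hydrogen in place of butyl giving a 3.2-fold higher number from compound 2 to compound 4 (0.51 log units; beyond the scatter) and hydrogen in place of decyl giving a 4.4-fold higher number from compound 1 to compound 4 (0.64 log units; beyond the scatter) so that a clear change appears only across wider gaps in chain length, while a 1.4-fold higher number from compound 1 to compound 2 (0.13 log units; within the scatter) is another step that goes against a smooth trend. Nothing available gives a reason for these steps.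

On these data alone, whether a chain shorter than hexyl would move the number further stays open. So does the effect of a chain carrying an amine or a carboxylic acid, or of a phenyl ring in place of the chain.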